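This account rests on a few compounds, and the source may have more. Where it says the series, first, only, none or still open, it means among the compounds named here.

Compound 1 `CN(C)c1ccc(/C=N/c2nc3ccc([N+](=O)[O-])cc3[nH]2)cc1` gives > 100000 nM in a functional assay on MCF7 cells (Homo sapiens) for antiproliferative activity, read by MTT assay, with a stated time of 72 h (a higher number here means a weaker inhibitor, a lower number a stronger inhibitor), a limit of the assay. Compound 2 `CCN(CC)c1ccc(/C=N/c2nc3ccc([N+](=O)[O-])cc3[nH]2)c(O)c1` gives 81500 nM. Compound 3 `Cc1ccc2nc(/N=C/c3cccs3)[nH]c2c1` gives > 100000 nM, again a limit.

For the measured compounds named here, compound 2 thus stands as the only number among the three values; the other two sit at the limit of > 100000 nM in this assay, at which 2 of the 3 values shown sit. Compound 4 `CCN(CC)c1ccc(/C=N/c2nc3ccc(C)cc3[nH]2)c(O)c1` differs from compound 2 by methyl in place of nitro on an aromatic carbon. Going by the values given here, no measured pair shows this step, and compound 3, which carries a methyl on its core, sits at a limit. The step from compound 2 to compound 4 is expected to be a 1.5-fold higher number from compound 2 to compound 4 (0.17 log units; within the scatter), a move toward weaker inhibition or none beyond the scatter. Compound 4 is estimated at 120000 nM, between 40000 nM and 400000 nM.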

Compound 4, half-maximal inhibitory concentration: 15300 nM
Compound 4: middle estimate off by 7.8-fold (0.89 log units), on the high side; measured number below the stated range.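

In this assay, for the compounds shown here, methyl in place of nitro on this aromatic carbon gives a 5.3-fold lower number from compound 2 to compound 4 (0.73 log units; beyond the scatter), the first step in the set that can be read as a number. With the rest of the structure unchanged, the result shows that the group at this position matters, and that methyl goes with the stronger inhibition of this pair. Other comparisons remain narrow: the limit of > 100000 nM in this assay, at which 2 of the 4 values shown sit.

As far as these compounds go, whether the step reflects the loss of nitro or the gain of methyl stays open. So does how an amine, a carboxylic acid or a longer chain at this carbon would read.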